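The compounds below may be only part of what the source reports. "The series", "measured", "known", "first", "only" and "open" are said of these compounds alone.

Measured compounds:
compound 1, `Oc1ccc(-c2cc(-c3cccs3)nc(-c3ccccc3Cl)c2)cc1`, 5870 nM
compound 2, `Oc1cccc(-c2cc(-c3ccsc3)nc(-c3cccc(Cl)c3)c2)c1`, 3540 nM
compound 3, `Oc1ccc(-c2cc(-c3ccsc3)nc(-c3ccccc3Cl)c2)cc1`, 6110 nM

These three were measured in a functional assay on T47D cells (Homo sapiens) for cytotoxicity, read by CCK-8 assay and cell counting, with a stated time of 2 days; on this read-out higher numbers stand for weaker inhibition and lower numbers for stronger inhibition. Compound 2 gives the lowest of the three numbers, yet its gaps to compound 1 and compound 3 both lie within the scatter, so no order among them is claimed. One change recurs: from compound 3 to compound 1, (thiophen-2-yl in place of thiophen-3-yl on an aromatic carbon), giving a 1.0-fold lower number from compound 3 to compound 1 (0.02 log units; within the scatter). Compound 4, `Oc1cccc(-c2cc(-c3cccc(Cl)c3)nc(-c3cccs3)c2)c1`, arises from compound 2 by the same kind of change, (thiophen-2-yl in place of thiophen-3-yl on an aromatic carbon); the surroundings differ, as in compound 3 the place is meta to a 2-chlorophenyl group and a 4-hydroxyphenyl group, whereas in compound 2 it is meta to a 3-chlorophenyl group and a 3-hydroxyphenyl group. How the cores of compound 2 and compound 3 differ is not broken down here. Because a 1.0-fold lower number from compound 3 to compound 1 (0.02 log units; within the scatter) stayed within the scatter, the step from compound 2 to compound 4 is expected to be a 1.0-fold higher number from compound 2 to compound 4 (0.01 log units; within the scatter). Compound 4 is thus estimated at 3600 nM, between 1500 nM and 9000 nM.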

Compound 4, half-maximal inhibitory concentration: 3410 nM
The estimate for compound 4 lay 1.1-fold (0.02 log units) above the measured number, within the range that was stated.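

In this assay, putting thiophen-2-yl in place of thiophen-3-yl on the core of compound 2 gives a 1.0-fold lower number from compound 2 to compound 4 (0.02 log units; within the scatter). Set beside the earlier case, the change carries across the two cores without a readable difference: the same change on two cores in this assay, a 1.0-fold lower number (0.02 log units; within the scatter) from compound 3 to compound 1 and a 1.0-fold lower number (0.02 log units; within the scatter) from compound 2 to compound 4, 1.0-fold (0.00 log units) apart, within the scatter of two such steps

Among the compounds shown here, this shows only that the exchange leaves the number within the scatter on these two cores, and it does not show that the two groups are equivalent on other cores or in other read-outs. The compounds shown leave open whether a different group at this place, such as an amine, a carboxylic acid or a longer alkyl chain, would move the number beyond the scatter.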